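Amide variation on a shared bicyclic core: anilide to cinnamide

The source may hold more compounds than are shown below. What is called first, only, known or untested is meant among the compounds shown, and "the series" means these compounds.

Measured so far:
compound 1 `CCCNc1cc2c(cn1)cc(NC(=O)c1cccc(-c3ccccc3)c1)c(=O)n2C` gives 6000 nM in a functional assay on MCF7 cells (Homo sapiens) for antiproliferative activity, read by MTT assay, with a stated time of 48 h; a lower number here means a stronger inhibitor, a higher number a weaker inhibitor
compound 2 `COc1cccc(C(=O)Nc2cc3cnc(NCCN(C)C)cc3n(C)c2=O)c1` gives 43300 nM in this assay
compound 3 `COc1cc(C(=O)Nc2cc3cnc(NCCN(C)C)cc3n(C)c2=O)cc(OC)c1OC` gives 21500 nM in this assay

Compound 2 stands at the high end of the three numbers in this assay; compound 3 sits within the scatter of it, while compound 1 lies beyond the scatter with the lower number. Compound 4 `CN(C)CCNc1cc2c(cn1)cc(NC(=O)/C=C/c1ccccc1)c(=O)n2C` differs from compound 2 in one place: 2-phenylethenyl in place of 3-methoxyphenyl on a carbonyl carbon. Among the measured compounds shown here, no measured pair in the set shows this change, so its direction is open. The amide substituent variations measured so far span a modest range, and compound 4 is expected to stay in that range. The expected step of a 1.7-fold lower number from compound 2 to compound 4 (0.24 log units; within the scatter) is small, not clearly beyond the scatter. Compound 4 is estimated at 25000 nM, within 8000 nM to 80000 nM.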

Compound 4, half-maximal inhibitory concentration: 27400 nM
Compound 4: middle estimate off by 1.1-fold (0.04 log units), on the low side; low and high end bracket the measured number.
By their numbers in this assay, from the lowest: compound 1; then compounds 3, 4 and 2 (each within the scatter of the next).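

Among the compounds shown here, at the amide carbonyl carbon, 2-phenylethenyl in place of 3-methoxyphenyl gives a 1.6-fold lower number from compound 2 to compound 4 (0.20 log units; within the scatter) in this assay, the first one-place reading at this position. Losing the methoxy oxygen and gaining a double bond outside aromatic rings therefore leaves the number within the scatter, so this swap alone does not separate the two groups. No supporting evidence bears on this result. Still open, on these data alone, is whether a saturated chain in place of the double bond would move the number beyond the scatter. The same applies to an amine or a carboxylic acid on the phenyl ring of the 2-phenylethenyl group.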